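Series notes: the step from compound 3 to compound 4

The source may hold more compounds than are shown below. What is called first, only, known or untested is meant among the compounds shown, and "the series" means these compounds.

Three compounds of the series have numbers in a functional assay on NCI/ADR cells (Homo sapiens) for cytotoxicity, read by sulforhodamine B assay; a lower number here means a stronger inhibitor of growth, a higher number a weaker inhibitor of growth. Compound 1 `CC1=CC[C@@H]([C@@](C)(O)CCCC(C)(C)NC=S)CC1` gives 16700 nM. Compound 2 `COc1ccc(/C=N\NC(=S)NC(C)(C)CCC[C@](C)(O)[C@@H]2CC=C(C)CC2)cc1` gives 6730 nM. Compound 3 `CC1=CC[C@@H]([C@@](C)(O)CCCC(C)(C)NC(=S)N/N=C\c2ccc(N(C)C)cc2)CC1` gives 25200 nM, the highest of the three numbers; compound 1 stands nearest, within the scatter, while compound 2 stands furthest, the gap being a 3.7-fold higher number from compound 2 to compound 3 (0.57 log units; beyond the scatter).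

Compound 4 `CC1=CC[C@@H]([C@@](C)(O)CCCC(C)(C)NC(=S)N/N=C\c2ccc(Cl)cc2)CC1` is not yet measured. It differs from compound 3 as follows: chloro in place of dimethylamino on an aromatic carbon

For the measured compounds named here, only one measured step touches the same aromatic carbon, the change from methoxy to dimethylamino, a 3.7-fold higher number from compound 2 to compound 3 (0.57 log units; beyond the scatter). Chloro matches neither group, and no measured compound carries chloro, so that step gives direction only loosely: the dimethylamino compound gave the highest number, and removing it is expected to move the number back toward compound 2, though not necessarily all the way. A modest step downward is therefore expected for compound 4, a 2.1-fold lower number from compound 3 to compound 4 (0.32 log units; beyond the scatter), but the range must stay wide because compound 2 with 6730 nM and compound 3 with 25200 nM bracket the plausible outcome. The estimate for compound 4 in this assay is 12000 nM, with a range from 4000 nM to 40000 nM.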

Compound 4, concentration for 50% growth inhibition: 7580 nM
Compound 4: middle estimate off by 1.6-fold (0.20 log units), on the high side, within the range that was stated.
By their numbers in this assay, from the lowest: compounds 2 and 4 (each within the scatter of the next); then compounds 1 and 3 (each within the scatter of the next).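

Notes on this position: in this assay, the aromatic carbon para to a large group now has three groups to compare, and a 3.3-fold lower number from compound 3 to compound 4 (0.52 log units; beyond the scatter) for chloro in place of dimethylamino adds a second step beyond the scatter to the one already seen, a 3.7-fold higher number from compound 2 to compound 3 (0.57 log units; beyond the scatter). Chloro and methoxy cannot be told apart here, with a 1.1-fold higher number from compound 2 to compound 4 (0.05 log units; within the scatter), so among these three groups dimethylamino alone stands apart, which the single earlier step could not show. No measurement is at hand that would explain this difference.

Going by these compounds, it remains open whether the higher number belongs to dimethylamino alone or to amines on this carbon more widely, which a primary amine or a pyrrolidine would test. On these data alone, it also remains open whether any other group, such as nitro or a carboxylic acid, would move the number clear of the level where compound 2 stands at 6730 nM and compound 4 stands at 7580 nM.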